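A few compounds are considered here, and "the series" means these few. Any claim that something is new, unique, unknown or untested is made for them only; others in the source may bear on it.

Compound 1 `COc1c(C)ccc2c1CCC2c1ncc[nH]1`: in a functional assay on CHO cells for agonist activity at Alpha-1D adrenergic receptor (Homo sapiens), read by FLIPR and calcium flux (a lower number here means that less compound is needed, a higher number that more compound is needed for the effect), compound 1 gives > 10000 nM, which is a limit of the assay.
Compound 2 `COc1cccc2c1CCC2c1ncc[nH]1`: in this assay compound 2 gives > 10000 nM, also a limit.
Compound 3 `CCS(=O)(=O)Nc1cccc(Cc2c[nH]cn2)c1`: in this assay compound 3 gives > 10000 nM, again a limit.

Compound 2 therefore stands only at a limit in this assay, and the same holds for every value shown: the limit of > 10000 nM in this assay, at which 3 of the 3 values shown sit. The one step shown, a step that the two limits leave unreadable from compound 1 to compound 2, has limits at both ends and its size cannot be read. Compound 4 `Cn1cc(-c2cccc3c2CCC3c2ncc[nH]2)cn1` differs from compound 2 by 1-methyl-1H-pyrazol-4-yl in place of methoxy on an aromatic carbon. Going by the values given here, no measured step bears on this change, and no size or direction of step in this assay can be derived from the numbers in hand. The step is nevertheless expected to be a step that the limit leaves unreadable from compound 2 to compound 4. Compound 4 is estimated at 15000 nM, with a range from 3000 nM to 60000 nM.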

Compound 4, half-maximal effective concentration: > 10000 nM
Compound 4: no number, only a limit; the forecaster's own chance of this, stated with the estimate: 70%; the middle value is on the limit's open side.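

No step can be read between compound 2 and compound 4, as both stand only at a limit in this assay: the limit of > 10000 nM in this assay, at which 4 of the 4 values shown sit.
The compounds shown leave open how far any of them lies beyond that limit, and whether any change among them alters the result.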